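Tolerability notes on one acid series, compound 4 pending

A few compounds are considered here, and "the series" means these few. Any claim that something is new, unique, unknown or untested is made for them only; others in the source may bear on it.

The series shares one core carrying a tert-butoxy-substituted acetic acid and differs at an amine nitrogen in a ring and on an aryl group. Compound 1 `Cc1ccc(-c2c3c(nc(C)c2[C@H](OC(C)(C)C)C(=O)O)CCN(CCCc2ccccc2)C3)cc1` carries 3-phenylpropyl on that nitrogen; compound 3 `Cc1ccc(-c2c3c(nc(C)c2[C@H](OC(C)(C)C)C(=O)O)CCN(c2ccccc2)C3)cc1` carries phenyl there; compound 2 `Cc1ccc(CCCN2CCc3nc(C)c([C@H](OC(C)(C)C)C(=O)O)c(-c4cc(F)c5c(c4C)CCCO5)c3C2)cc1F` carries a fluorinated, methylated propyl chain and a fused bicyclic aryl group.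

All three were run in an ADME assay on MT2 cells (Homo sapiens) for cytotoxicity, read by XTT assay, with a stated time of 4 days; a lower number here means that less compound is tolerated, a higher number that more compound is tolerated. Compound 1 reports only a limit, > 40000 nM. Compound 3 likewise reports a limit, > 40000 nM. Compound 2 also reports a limit, > 40000 nM. Within the data shown here, the one single-point comparison, a step that the two limits leave unreadable from compound 1 to compound 3, is therefore unreadable. Compound 2 stands where every value shown stands: at the limit of > 40000 nM in this assay, at which 3 of the 3 values shown sit, with no number beneath it.

Compound 4 `Cc1nc2c(c(-c3cc(F)c4c(c3C)CCCO4)c1[C@H](OC(C)(C)C)C(=O)O)CN(CC1CC1c1ccccc1)CC2` differs from compound 2 in one place: 2-phenylcyclopropyl in place of 2-(3-fluoro-4-methylphenyl)ethyl on a saturated chain carbon bound to an amine nitrogen in a ring. Among the measured compounds shown here, no measured step changes this part of the molecule within a readable range; the only step available is the unreadable one from compound 1 to compound 3. Nothing in the series points to a readable step in this assay in either direction. The expectation for compound 4 is accordingly a limit again, the step from compound 2 to compound 4 estimated as a step that the limit leaves unreadable from compound 2 to compound 4. Compound 4 is thus expected to give 50000 nM, within 20000 nM to 120000 nM.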

Compound 4, half-maximal cytotoxic concentration: > 40000 nM
Compound 4 ended at the assay's limit; the forecaster's own chance of this, stated with the estimate: 80%; the middle value lies beyond the limit too.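

Compound 2 and compound 4 both report only a limit in this assay, so no step between them can be read: the limit of > 40000 nM in this assay, at which 4 of the 4 values shown sit.

The compounds shown leave open how 2-phenylcyclopropyl and 2-(3-fluoro-4-methylphenyl)ethyl compare in tolerability, and where any compound in the series would give a value that is not a limit.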